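Varying the carbonyl substituent at the chain terminus

The source may hold more compounds than are shown below. What is called first, only, known or untested is meant among the compounds shown, and "the series" means these compounds.

Measured compounds:
compound 1 `COc1cc(NC(C)CCCNC(=O)NCc2ccncc2)c2ncccc2c1` — 48000 nM
compound 2 `COc1cc(NC(C)CCCNC(=O)NCc2ccccc2)c2ncccc2c1` — 30000 nM
compound 3 `CCN(CC)C(=O)NCCCC(C)Nc1cc(OC)cc2cccnc12` — > 100000 nM

In a functional assay on NCI-H460 cells (Homo sapiens), read by MTT assay, with a stated time of 72 h (on this read-out higher numbers stand for weaker inhibition and lower numbers for stronger inhibition), compound 1 gives 48000 nM and compound 2 gives 30000 nM; the pair is linked by a 1.6-fold lower number from compound 1 to compound 2 (0.20 log units; within the scatter), so the two cannot be ranked. For compound 3 the read-out of > 100000 nM in this assay is a limit, not a number; it sits at the limit of > 100000 nM in this assay, at which 1 of the 3 values shown sits. Compound 3 therefore stands at the weak end of what has been measured, with an at least 2.0-fold higher number from compound 1 to compound 3 (0.31 log units; beyond the scatter) and an at least 3.3-fold higher number from compound 2 to compound 3 (0.52 log units; beyond the scatter) both beyond the scatter.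

Compound 4 `COc1cc(NC(C)CCCNC(=O)n2nnc3ccccc32)c2ncccc2c1` is the next member, differing from compound 3 by a group of 9 heavy atoms (6 carbon, 3 nitrogen; one five-membered aromatic ring with 3 hetero atoms, one six-membered aromatic ring of carbon only) in place of a group of 5 heavy atoms (4 carbon, 1 nitrogen; no ring), on a carbonyl carbon. The two measured steps that bear on this position both run from a ring-bearing group on the carbonyl carbon to the ring-free diethylamino, and both raised the number; compound 4 reverses that direction by restoring a ring-bearing group there. The step into compound 4 is therefore expected to lower the number in this assay, by roughly an at least 2.2-fold lower number from compound 3 to compound 4 (0.34 log units; beyond the scatter), though its exact size is uncertain because compound 3 shows only a limit (the limit of > 100000 nM in this assay, at which 1 of the 3 values shown sits). Compound 4 is expected to give about 45000 nM in this assay, estimated to fall between 15000 nM and 150000 nM.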

Compound 4, half-maximal inhibitory concentration: > 100000 nM
Compound 4: a limit, no number; the forecaster's own chance of this, stated with the estimate: 35%; middle value at least 2.2-fold (0.34 log units) from the limit.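

In this assay compound 4 gives > 100000 nM, a limit and not a number. Within the data shown here, putting the group with a five-membered aromatic ring with 3 hetero atoms and a six-membered aromatic ring of carbon only on the carbonyl carbon, in place of benzylamino, gives an at least 3.3-fold higher number from compound 2 to compound 4 (0.52 log units; beyond the scatter), and in place of ((pyridin-4-yl)methyl)amino it gives an at least 2.0-fold higher number from compound 1 to compound 4 (0.31 log units; beyond the scatter), so a ring-bearing group at this position does not on its own keep the read-out measurable as a number, which the earlier compounds could not show. The ring-free diethylamino and this ring-bearing group now end at the same place, and the limit is shared by two compounds: the limit of > 100000 nM in this assay, at which 2 of the 4 values shown sit.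

On these data alone, the step between the two limit compounds cannot be read, so their order stays unknown. Also open, as far as these compounds go, is whether the values of the benzylamino and ((pyridin-4-yl)methyl)amino compounds depend on the saturated carbon that separates their ring from the nitrogen, which a group such as anilino or 2-phenylethylamino on the carbonyl carbon would address.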